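This account rests on a few compounds, and the source may have more. Where it says the series, first, only, none or still open, it means among the compounds named here.

Measured so far in an ADME assay on MT4 cells (Homo sapiens) for cytotoxicity, read by MTT assay, with a stated time of 5 days; on this read-out lower numbers stand for higher toxicity in this test and higher numbers for lower toxicity in this test:
Compound 1 `Cc1cnc(Nc2ccc(C#N)cc2)nc1OCC(=O)Nc1ccc(F)cc1` gives > 331000 nM, a limit of the assay rather than a number.
Compound 2 `Cc1cnc(Nc2ccc(C#N)cc2)nc1OCC(=O)Nc1ccc(Cl)cc1` gives > 317000 nM, again a limit rather than a number.
Compound 3 `Cc1cnc(Nc2ccc(C#N)cc2)nc1OCC(=O)Nc1cccc(Cl)c1` gives 144000 nM.

For the measured compounds named here, compound 3 thus stands as the only compound of the three with an actual number; the other two values are limits. The steps of an at least 2.2-fold lower number from compound 1 to compound 3 (0.36 log units; beyond the scatter) and an at least 2.2-fold lower number from compound 2 to compound 3 (0.34 log units; beyond the scatter) both run to a lower number and both lie beyond the scatter, though their full size cannot be fixed because compound 1 sits at the limit of > 331000 nM in this assay, at which 1 of the 3 values shown sits, and compound 2 sits at the limit of > 317000 nM in this assay, at which 1 of the 3 values shown sits. The step that the two limits leave unreadable from compound 1 to compound 2 is unreadable for the same reason.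

Compound 4 `Cc1cnc(Nc2ccc(C#N)cc2)nc1OCC(=O)Nc1ccccc1Cl` differs from compound 3 by 2-chlorophenyl in place of 3-chlorophenyl on an amide-type nitrogen. Going by these compounds, the two readable steps show that shifting the chlorine round the ring on the amide-type nitrogen moved the value from a limit to a number; for the 2-chlorophenyl the direction is untested, so a number of the same order as compound 3, perhaps somewhat higher, is the working expectation. Compound 4 is estimated at 200000 nM, range 90000 nM to 400000 nM, which is expected to mean a 1.4-fold higher number from compound 3 to compound 4 (0.14 log units; within the scatter).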

Compound 4, half-maximal cytotoxic concentration: 197000 nM
Estimate against measurement, compound 4: 1.0-fold (0.01 log units) above; the range from low to high includes it.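

In this assay the 2-chlorophenyl in place of 3-chlorophenyl on the amide-type nitrogen gives a 1.4-fold higher number from compound 3 to compound 4 (0.14 log units; within the scatter) and so does not separate these two chlorophenyl isomers. Compound 1 and compound 2 stand at limits of the assay rather than numbers, so an at least 1.6-fold lower number from compound 2 to compound 4 (0.20 log units; that floor lies within the scatter) and an at least 1.6-fold lower number from compound 1 to compound 4 (0.22 log units; that floor lies within the scatter) are floors only, and unlike the floors for compound 3 they do not clear the scatter. Separation beyond the scatter from the limit compounds is thus shown for the 3-chlorophenyl alone, although the 2-chlorophenyl also gives an actual number rather than a limit.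

How far compound 4 truly lies from compound 1 and compound 2 cannot be read. Also open, going by these compounds, is how a carboxylic acid or a dimethylamino group on this phenyl ring would read in this assay in place of the chlorine.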